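A Methyl Group on the Benzoyl Ring of Compound 1

The source may report more compounds than this note shows. Statements on the series, on what has been measured and on what is new or still open speak of the compounds shown alone.

Compound 1, `N#Cc1c(F)c(F)c(C(C(=O)c2ccccc2)=C2NCCN2)c(C#N)c1F`, gives 0.2 ug/mL in a functional assay on HL-60 cells (Homo sapiens) for antiproliferative activity, read by MTT assay; a higher number here means a weaker inhibitor, a lower number a stronger inhibitor.
Compound 2, `N#Cc1c(F)c(C#N)c(C(C(=O)c2ccccc2)=C2NCCN2)c(F)c1Nc1ccccc1`, gives 0.3 ug/mL.

Compound 1 stands at the lowest of the two numbers, and its gap to compound 2, a 1.5-fold higher number from compound 1 to compound 2 (0.18 log units; within the scatter), is within the scatter. Compound 3, `Cc1ccc(C(=O)C(=C2NCCN2)c2c(F)c(F)c(C#N)c(F)c2C#N)cc1`, is not yet measured. It differs from compound 1 by methyl in place of hydrogen on an aromatic carbon. Among the measured compounds shown here, the one measured step, a 1.5-fold higher number from compound 1 to compound 2 (0.18 log units; within the scatter), alters a different part of the shared core and was within the scatter, so no guide exists for a change on the benzoyl ring. The expected step is a 1.3-fold higher number from compound 1 to compound 3 (0.10 log units; within the scatter), within the scatter. Compound 3 is estimated at 0.25 ug/mL, with a range from 0.1 ug/mL to 0.6 ug/mL.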

Compound 3, half-maximal inhibitory concentration: 0.04 ug/mL
Estimate against measurement, compound 3: 6.3-fold (0.80 log units) above, outside the stated range (below it).
By their numbers in this assay, from the lowest: compound 3; then compounds 1 and 2 (each within the scatter of the next).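

The benzoyl ring turns out to be a place where one added carbon counts: in this assay, methyl in place of hydrogen gives a 5.0-fold lower number from compound 1 to compound 3 (0.70 log units; beyond the scatter). This is the first change shown that moves the number beyond the scatter, since anilino in place of fluoro gave only a 1.5-fold higher number from compound 1 to compound 2 (0.18 log units; within the scatter). Nothing measured here gives a reason for this drop.

A single example cannot show whether the effect belongs to methyl itself or would appear with other groups at this place. On these data alone, whether ethyl, methoxy or chloro would lower the number further or lose the improvement remains open.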